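Swapping the pyridinyl of a topoisomerase hit for thiophenyl

The source may hold more compounds than are shown below. What is called first, only, known or untested is meant among the compounds shown, and "the series" means these compounds.

Measured in an assay on isolated protein for inhibition of DNA topoisomerase 1 (Homo sapiens), with a stated time of 30 min, tested at 100 uM; on this read-out lower numbers stand for a weaker effect and higher numbers for a stronger effect at the one concentration tested:
- compound 1 `Oc1ccc(-c2cc(-c3ccccn3)nc(-c3ccccc3Cl)c2)cc1`: 5.2%
- compound 2 `Oc1ccc(-c2cc(-c3cccc(Cl)c3)nc(-c3ccccn3)c2)cc1`: 59.4%

For the measured compounds named here, compound 2 holds the highest of the two numbers; the only neighbour, compound 1, lies lower by a number 54.2 percentage points higher from compound 1 to compound 2 (beyond the scatter). Compound 3 `Oc1ccc(-c2cc(-c3cccc(Cl)c3)nc(-c3cccs3)c2)cc1` differs from compound 2 by thiophen-2-yl in place of pyridin-2-yl on an aromatic carbon. Going by the values given here, the single measured step, a number 54.2 percentage points higher from compound 1 to compound 2 (beyond the scatter), concerns the chlorophenyl group only, while the pyridin-2-yl group is shared by compound 1 and compound 2, so no step bears on the present change. The data give no basis for a step in either direction in this assay, and the expectation for compound 3 therefore rests on compound 2 alone, with a wide range. Compound 3 is expected to give 50%, within 15% to 80%. This estimate implies an expected step of a number 9.4 percentage points lower from compound 2 to compound 3 (within the scatter), which is not beyond the scatter.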

Compound 3, a percentage reported as inhibition, at one concentration (the size of the read-out at that concentration, not a potency): 52.4%
The estimate for compound 3 lay 2.4 percentage points below the measured number; the range from low to high includes it.
By their numbers in this assay, from the lowest: compound 1; then compounds 3 and 2 (each within the scatter of the next).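

In this assay, the exchange of pyridin-2-yl for thiophen-2-yl, on the aromatic carbon next to the ring nitrogen, gives a number 7 percentage points lower from compound 2 to compound 3 (within the scatter). With the 3-chlorophenyl and 4-hydroxyphenyl groups held fixed, this position therefore accepts a five-membered aromatic ring with sulfur as readily as a six-membered one with nitrogen, so for this pair the nitrogen of pyridin-2-yl is not needed to keep the read-out at the one concentration tested. No measurement at hand explains this tolerance.

Going by these compounds, whether a furan-2-yl, a plain phenyl or a pyridin-2-yl carrying an amine would hold the number at this position remains open. So does whether the same exchange would behave alike with the 2-chlorophenyl group of compound 1 in place of 3-chlorophenyl.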